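A few compounds are considered here, and "the series" means these few. Any claim that something is new, unique, unknown or untested is made for them only; others in the source may bear on it.

Compound 2 `Cc1ccc(Nc2nc(SCc3cn(Cc4ccc(F)cc4)nn3)nc(-c3ccccc3)c2C#N)cc1` gives 42700 nM in a functional assay on ECa-109 cells (Homo sapiens) for inhibition, read by MTT assay, with a stated time of 72 h (a lower number here means a stronger inhibitor, a higher number a weaker inhibitor), the higher of the two numbers measured, while compound 1 `Cc1cccc(Nc2nc(SCc3cn(Cc4ccccc4Cl)nn3)nc(-c3ccccc3)c2C#N)c1` gives 15600 nM in this assay. Compound 3 `Cc1ccc(Nc2nc(SCc3cn(Cc4ccccc4Cl)nn3)nc(-c3ccccc3)c2C#N)cc1` is reached from compound 2 by 2-chlorophenyl in place of 4-fluorophenyl on a saturated chain carbon bound to an aromatic nitrogen. Among the measured compounds shown here, no measured pair isolates this change, but compound 1 also carries the 2-chlorobenzyl group and lies at 15600 nM, so a modest move toward a lower number is expected, with the step of a 1.9-fold lower number from compound 2 to compound 3 (0.29 log units; within the scatter) expected to sit near the edge of the scatter. Compound 3 is therefore estimated at 22000 nM, within a range from 8000 nM to 55000 nM.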

Compound 3, half-maximal inhibitory concentration: > 64000 nM
Compound 3 gave a limit, no number; the forecaster's own chance of this, stated with the estimate: 5%; at least 2.9-fold (0.46 log units) between middle value and limit.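

In this assay compound 3 gives > 64000 nM, which is a limit and not a number. With 2-chlorophenyl in place of 4-fluorophenyl on a saturated chain carbon bound to an aromatic nitrogen, the result is an at least 1.4-fold higher number from compound 2 to compound 3 (0.17 log units; that floor lies within the scatter), so this change gives no lower number here, though its size stays unfixed. The firmer finding concerns 4-methylphenyl in place of 3-methylphenyl on a nitrogen on an aromatic ring, with an at least 4.1-fold higher number from compound 1 to compound 3 (0.61 log units; beyond the scatter) while the 2-chlorobenzyl group stays the same.

The compounds shown leave open how large the benzyl step really is. They also leave open whether an amine or a carboxylic acid in place of the methyl would give a lower number.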